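The source may report more compounds than this note shows. Statements on the series, on what has been measured and on what is new or still open speak of the compounds shown alone.

Compound 3 `O=C(Nc1cccc(NC(=O)c2ccccc2Cl)c1)c1cccc(Cl)c1` is the only one of the three measured compounds to return a number in an in vitro functional assay on HEK293-A cells for antagonist activity at metabotropic glutamate receptor 5 (Rattus norvegicus), read by calcium flux (a lower number here means a stronger inhibitor, a higher number a weaker inhibitor), at 2620 nM. Compound 1 `COc1ccccc1C(=O)Nc1cccc(NC(=O)c2ccccc2Cl)c1` gives only a limit of the assay in this assay, > 30000 nM. Compound 2 `COc1ccccc1C(=O)Nc1cccc(NC(=O)c2ccc(Cl)cc2)c1` likewise gives only a limit, > 30000 nM. Within the data shown here, the step of an at least 11-fold lower number from compound 1 to compound 3 (1.05 log units; beyond the scatter) is the one readable step; the step that the two limits leave unreadable from compound 1 to compound 2 is not, because both ends sit at the limit of > 30000 nM in this assay, at which 2 of the 3 values shown sit.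

Compound 4 `O=C(Nc1cccc(NC(=O)c2cccc(Cl)c2)c1)c1ccc(Cl)cc1` differs from compound 3 by 4-chlorophenyl in place of 2-chlorophenyl on a carbonyl carbon. Among the measured compounds shown here, this is the same exchange as from compound 1 to compound 2, whose size the two limits hide, so no measured step gives the size or direction of the change to be expected here; the change from compound 1 to compound 3, with a different group exchanged, offers no guide either. Compound 4 is therefore expected to stay roughly where compound 3 stands, with wide uncertainty: the estimated step is a 2.3-fold higher number from compound 3 to compound 4 (0.36 log units; beyond the scatter). Compound 4 is expected to give about 6000 nM, within a range from 1500 nM to 30000 nM.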

Compound 4, half-maximal inhibitory concentration: > 30000 nM
Compound 4: a limit, no number; the forecaster's own chance of this, stated with the estimate: 30%; middle value at least 5.0-fold (0.69 log units) from the limit.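

In this assay, the exchange of 2-chlorophenyl for 4-chlorophenyl on a carbonyl carbon now has a readable size where it previously had none: an at least 11-fold higher number from compound 3 to compound 4 (1.05 log units; beyond the scatter). Compound 3 and compound 4 hold the same atoms, joined differently, so the place of one chlorine on this ring separates a measured number from a value at the limit of the assay: the limit of > 30000 nM in this assay, at which 3 of the 4 values shown sit. The 2-chlorophenyl group does not secure a number by itself, since compound 1 also carries it and gives only a limit, > 30000 nM.

On these data alone, the steps with a limit at both ends cannot be read, and how far compound 4 lies past its limit stays open. Also open, as far as these compounds go, is whether an unsubstituted phenyl, a pyridine ring or an amine in place of the 2-chlorophenyl of compound 3 would give a lower or higher number.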